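Esterifying the second acid of a solubility-limited pair

The source may report more compounds than this note shows. Statements on the series, on what has been measured and on what is new or still open speak of the compounds shown alone.

Three compounds with the same core have been examined in a physicochemical assay for solubility, read by HPLC, in phosphate buffer, with a stated time of 24 h, at pH 5.5, tested at 120 uM; on this read-out lower numbers stand for lower solubility and higher numbers for higher solubility. Compound 1 `COC(=O)CC[C@H](NC(=O)c1c(C)[nH]c(/C=C2\C(=O)Nc3ccc(C(=O)O)cc32)c1C)C(=O)OC` gives 30000 nM. Compound 3 `COC(=O)CC[C@H](NC(=O)c1c(C)[nH]c(/C=C2\C(=O)Nc3ccc(C(=O)OC)cc32)c1C)C(=O)OC` carries a methyl in place of hydrogen on an oxygen next to a carbonyl group, and in this assay compound 3 gives < 5000 nM, which is a limit of the assay rather than a number. That change gave an at least 6.0-fold lower number from compound 1 to compound 3 (0.77 log units; beyond the scatter). Compound 2 `COC(=O)CC[C@H](NC(=O)c1ccc2c(c1)/C(=C/c1[nH]c(C)c(C(=O)O)c1C)C(=O)N2)C(=O)OC`, in which the free carboxy sits on the pyrrole side instead, gives < 5000 nM in this assay, again a limit. So compound 2 stands at the limit of < 5000 nM in this assay, at which 2 of the 3 values shown sit, with no exact number known for it.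

Compound 4 `CCOC(=O)c1c(C)[nH]c(/C=C2\C(=O)Nc3ccc(C(=O)N[C@@H](CCC(=O)OC)C(=O)OC)cc32)c1C` differs from compound 2 by ethyl in place of hydrogen on an oxygen next to a carbonyl group. Among the compounds with values here, the only measured step that bears on it is the one from compound 1 to compound 3, where capping an oxygen next to a carbonyl group with methyl lowered solubility at least modestly, down to the limit. Capping the remaining carboxy of compound 2 with ethyl is expected to move solubility in the same direction, or at best leave it at the limit. Compound 4 is therefore estimated at 1500 nM in this assay, in a range from 300 nM to 5000 nM, most probably reported only as a limit. The expected step is a step that the limit leaves unreadable from compound 2 to compound 4.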

Compound 4, solubility: < 1000 nM
Compound 4 ended at the assay's limit (the forecaster's own chance of this, stated with the estimate: 85%); middle value at least 1.5-fold (0.17 log units) away from the limit.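

Compound 2 and compound 4 are both reported only as limits of the assay, not as numbers, and the step between them cannot be read. The compounds shown leave open the actual solubility of compound 2 and compound 4, and whether going from carboxy to ethoxycarbonyl on this core changes solubility at all.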